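A few compounds are considered here, and "the series" means these few. Any claim that something is new, unique, unknown or untested is made for them only; others in the source may bear on it.

Measured so far in an ADME assay (liver) for metabolic stability, with Liver microsome (Rattus norvegicus) as the target, using microsomes and NADPH, with a stated time of 30 min, tested at 1 uM; on this read-out lower numbers stand for slow clearance and higher numbers for fast clearance:
- compound 1 `COCC#Cc1cc(C(O)(C(F)(F)F)C(F)(F)F)cnc1N1CCN(S(=O)(=O)c2ccc(N)nc2)CC1`: 399 mL.min-1.g-1
- compound 2 `COc1cncc(-c2cc(C(O)(C(F)(F)F)C(F)(F)F)cnc2N2CCN(S(=O)(=O)c3ccc(N)nc3)CC2)c1`: 58 mL.min-1.g-1
- compound 3 `Nc1ccc(S(=O)(=O)N2CCN(c3ncc(C(O)(C(F)(F)F)C(F)(F)F)cc3-c3ccc4c(c3)CC(=O)N4)CC2)cn1`: 119 mL.min-1.g-1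

Compound 3 stands in the middle of the three numbers, above compound 2 and below compound 1. The next comparison is with compound 4 `Nc1ccc(S(=O)(=O)N2CCN(c3ncc(C(O)(C(F)(F)F)C(F)(F)F)cc3-c3ccc4[nH]ncc4c3)CC2)cn1`, which changes one group: a group of 9 heavy atoms (7 carbon, 2 nitrogen; one five-membered aromatic ring with 2 hetero atoms, one six-membered aromatic ring of carbon only) in place of a group of 10 heavy atoms (8 carbon, 1 nitrogen, 1 oxygen; one five-membered non-aromatic ring with 1 hetero atom, one six-membered aromatic ring of carbon only), on an aromatic carbon. The 1H-indazol-5-yl group enters on an aromatic carbon of a six-membered aromatic ring with 1 nitrogen.

Among the compounds with values here, no measured step makes this exact exchange, but three steps change the same place. Two of them replace the 3-methoxyprop-1-yn-1-yl group, which has no ring: a 6.9-fold lower number from compound 1 to compound 2 (0.84 log units; beyond the scatter) and a 3.4-fold lower number from compound 1 to compound 3 (0.53 log units; beyond the scatter). Both are modest, and they bear on the present change only loosely. Within the data shown here, the closest precedent swaps one ring-bearing group for another: a 2.1-fold higher number from compound 2 to compound 3 (0.31 log units; beyond the scatter). That step is also modest and sets the likely scale here. The data do not settle the direction, so the estimate stays close to compound 3 at 119 mL.min-1.g-1, with a wide range on both sides.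

The expected step is a 1.1-fold lower number from compound 3 to compound 4 (0.05 log units; within the scatter), so no clear change is expected in this assay. The estimated value for compound 4 is 105 mL.min-1.g-1, with an expected range from 50 mL.min-1.g-1 to 230 mL.min-1.g-1.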

Compound 4, intrinsic clearance in microsomes: 88 mL.min-1.g-1
The estimate for compound 4 lay 1.2-fold (0.08 log units) above the measured number; the measured number falls inside the stated range.
By their numbers in this assay, from the lowest: compounds 2, 4 and 3 (each within the scatter of the next, the first and the last beyond it); then compound 1.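

In this assay the 1H-indazol-5-yl group, on an aromatic carbon of a six-membered aromatic ring with 1 nitrogen, cannot be told apart from either ring-bearing group already seen at this place, with a 1.4-fold lower number from compound 3 to compound 4 (0.13 log units; within the scatter) and a 1.5-fold higher number from compound 2 to compound 4 (0.18 log units; within the scatter). Compound 2 and compound 3 had stood just beyond the scatter of each other, and compound 4 now links them, so the three ring-bearing groups form one continuous band, while compound 1, with its 3-methoxyprop-1-yn-1-yl group, stays apart, with a 4.5-fold lower number from compound 1 to compound 4 (0.66 log units; beyond the scatter). No measurement shown accounts for the band or for the distance to compound 1.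

Going by these compounds, the open-chain side rests on compound 1 alone, so it remains open whether its number belongs to the 3-methoxyprop-1-yn-1-yl group in particular or to chains without a ring more generally. On these data alone, it also remains open how a morpholine ring, an amine or a carboxylic acid at this same place would read in this assay, and whether the band would extend to any of them.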